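Replacing a cyclohexyl ring with a fluorinated chain

The compounds below may be only part of what the source reports. "The series", "measured", "known", "first", "only" and "open" are said of these compounds alone.

Compound 3 (`N[C@H]1CC[C@H](CN(C[C@H]2Cc3ccccc3CN2)[C@H]2CCCc3cccnc32)CC1`) shares its core with two measured relatives. In an ADME assay on microsomes from liver (Rattus norvegicus) for metabolic stability (a lower number here means that less of the compound is left, a higher number that more of the compound is left), compound 3 gives 51% and sits in the middle: compound 1 (`C/C(CN)=C(/F)CN(C[C@H]1Cc2ccccc2CN1)[C@H]1CCCc2cccnc21`) gives 72% and compound 2 (`C/C(=C/CN(C[C@H]1Cc2ccccc2CN1)[C@H]1CCCc2cccnc21)CN`) gives 1% on the same core. Compound 4 (`C/C(CN(C[C@H]1Cc2ccccc2CN1)[C@H]1CCCc2cccnc21)=C(/F)CN`) differs from compound 3 in one place (3-amino-2-fluoro-1-methylprop-1-en-1-yl in place of 4-aminocyclohexyl on a saturated chain carbon bound to an amine nitrogen): 3-amino-2-fluoro-1-methylprop-1-en-1-yl in place of 4-aminocyclohexyl on a saturated chain carbon bound to an amine nitrogen.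

Going by the values given here, three measured steps bear on this. Going to the fluorine-free chain brought a large fall (a number 71 percentage points lower from compound 1 to compound 2 (beyond the scatter)) and the ring brought a large rise over that same chain (a number 50 percentage points higher from compound 2 to compound 3 (beyond the scatter)). The nearest comparison is a modest step (a number 21 percentage points lower from compound 1 to compound 3 (beyond the scatter)) but its fluorinated chain is not the incoming one, so these steps fix no direction. No step beyond the scatter is therefore expected (a number 6 percentage points lower from compound 3 to compound 4 (within the scatter)) although the uncertainty is wide. The estimated value for compound 4 is 45% with 15% to 75% as its expected range.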

Compound 4, percent of the compound remaining: 61%
Compound 4: middle estimate off by 16 percentage points, on the low side, and the stated range covers the measured number.
By their numbers in this assay, from the lowest: compound 2; then compounds 3 and 4 (each within the scatter of the next); then compound 1.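

At this position, the 4-amino-3-fluoro-2-methylbut-2-en-1-yl chain can take the place of the ring-bearing (4-aminocyclohexyl)methyl group in this assay without a change beyond the scatter (a number 10 percentage points higher from compound 3 to compound 4 (within the scatter)). Moving to this fluorinated chain from the fluorine-free chain of compound 2 gives a large difference (a number 60 percentage points higher from compound 2 to compound 4 (beyond the scatter)), so the very low number of compound 2 is not shared by either fluorinated chain. The arrangement of the chain still counts, since the two fluorinated chains are separated by a modest step (a number 11 percentage points lower from compound 1 to compound 4 (beyond the scatter)).

The compounds shown leave open how the 4-amino-2-methylbut-2-en-1-yl chain, which is the chain of compound 4 with hydrogen in place of fluorine, would compare, so the part played by the fluorine in this arrangement stays unsettled. Nothing available explains any of these differences.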